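A few compounds are considered here, and "the series" means these few. Any claim that something is new, unique, unknown or untested is made for them only; others in the source may bear on it.

Compound 1 `CC1=CCC[C@](C)(CC/C(C)=C/CC2=C(O)C(=O)C=C(N[C@@H](C(=O)O)[C@@H](C)O)C2=O)[C@@H]1C`: > 10 ug/mL, a limit
Compound 2 `CC1=CCC[C@](C)(CC/C(C)=C/CC2=C(O)C(=O)C=C(N[C@@H](C(=O)O)C(C)C)C2=O)[C@@H]1C`: > 10 ug/mL, a limit

In an ADME assay on KB cells (Homo sapiens) for cytotoxicity, with a stated time of 48 h (a higher number here means a weaker inhibitor, a lower number a stronger inhibitor), compound 2 gives > 10 ug/mL, which is a limit and not a number. Compound 1, which carries a 1-hydroxyethyl group, also gives > 10 ug/mL, again a limit. The record so far is therefore (the limit of > 10 ug/mL in this assay, at which 2 of the 2 values shown sit).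

Compound 3 `CC1=CCC[C@](C)(CC/C(C)=C/CC2=C(O)C(=O)C=C(N[C@@H](C(=O)O)[C@H](C)O)C2=O)[C@@H]1C` has 1-hydroxyethyl in place of isopropyl on a saturated chain carbon bound to an amine nitrogen and a carbonyl carbon.

Among the measured compounds shown here, the only measured step, a step that the two limits leave unreadable from compound 1 to compound 2, is the same exchange of groups in the opposite direction, and it offers no size to carry over. No step beyond the scatter is therefore expected in this assay, and no direction can be predicted.

The estimated step is a step that the limit leaves unreadable from compound 2 to compound 3. The assay will most likely report another limit. For compound 3, the expected value is 15 ug/mL, within an estimated range of 8 ug/mL to 30 ug/mL.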

Compound 3, half-maximal inhibitory concentration: > 10 ug/mL
Compound 3: no number, only a limit (the forecaster's own chance of this, stated with the estimate: 85%); the middle value lies beyond the limit too.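

In this assay, among the compounds shown here, compound 3 gives > 10 ug/mL, a limit and not a number, so no step among compound 1, compound 2 and compound 3 can be read: the limit of > 10 ug/mL in this assay, at which 3 of the 3 values shown sit. From the compounds shown here alone, whether these compounds differ in cytotoxicity at all, including the mirror-drawn stereocentre pair compound 1 and compound 3, stays open.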